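Swapping the benzyl arm for a short ether chain

A few compounds are considered here, and "the series" means these few. Any claim that something is new, unique, unknown or untested is made for them only; others in the source may bear on it.

Of the compounds shown here, two built on the same core have been measured in an assay on CHO cells for displacement of a labelled ligand from adenosine receptor A1 (Homo sapiens) (on this read-out higher numbers stand for weaker inhibition and lower numbers for stronger inhibition), so far. Compound 1 `CCOC(=O)c1cnc(NC2CCCC2)n2nc(-c3ccco3)nc12`, bearing a cyclopentyl group on the ring nitrogen, gives 34.4 nM. Going by the values given here, compound 2 `CCOC(=O)c1cnc(NCc2ccc(F)cc2)n2nc(-c3ccco3)nc12`, where a 4-fluorobenzyl group replaces that cyclopentyl, gives 932 nM; the step of a 27-fold higher number from compound 1 to compound 2 (1.43 log units; beyond the scatter) is a large one, and compound 2 therefore stands at the weaker end of the two numbers known. Compound 3 `CCOC(=O)c1cnc(NCCOC)n2nc(-c3ccco3)nc12` has not yet been measured. It differs from compound 2 by methoxymethyl in place of 4-fluorophenyl on a saturated chain carbon bound to a nitrogen on an aromatic ring. Among the compounds with values here, no measured step changes the chain on this nitrogen in the same way, so only the step from compound 1 to compound 2 bears on it, and that step speaks for a large effect of what hangs from the ring nitrogen. With the aromatic arm gone and a small open chain in its place, compound 3 is expected to land near the value of compound 2 rather than to recover the number of compound 1, the estimated step being a 1.6-fold lower number from compound 2 to compound 3 (0.19 log units; within the scatter). Compound 3 is thus estimated at 600 nM, within a range from 150 nM to 2500 nM.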

Compound 3, inhibition constant: 2270 nM
The estimate for compound 3 lay 3.8-fold (0.58 log units) below the measured number; low and high end bracket the measured number.
By their numbers in this assay, from the lowest: compound 1; then compound 2; then compound 3.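

In this assay, taking the aromatic ring out of the arm did not bring the number back towards that of compound 1: the change gave a 2.4-fold higher number from compound 2 to compound 3 (0.39 log units; beyond the scatter) and so moved further away, which means the poor result with 4-fluorobenzyl is not specific to that aromatic group. Measured directly against cyclopentyl, the 2-methoxyethyl group gives a 66-fold higher number from compound 1 to compound 3 (1.82 log units; beyond the scatter) and thereby shows that two very different arms on this nitrogen, one carrying a six-membered aromatic ring and one with no ring at all, both stand far above compound 1, leaving cyclopentyl with the lowest number of the three groups. Nothing measured here accounts for this order.

As far as these compounds go, it remains open whether the lower number of compound 1 goes with a saturated carbon ring as such or would also appear with an open hydrocarbon chain, which a cyclohexyl group and an n-butyl group on the same nitrogen would separate, and whether a 2-hydroxyethyl or 2-aminoethyl arm would differ from 2-methoxyethyl. Also open, from the compounds shown here alone, is whether the same order of groups holds with a carboxylic acid in place of the ethyl ester.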